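From methoxy to 2-hydroxyethyl on the shared core

This account rests on a few compounds, and the source may have more. Where it says the series, first, only, none or still open, it means among the compounds named here.

In a functional assay on NCI-H1299 cells (Homo sapiens), read by flow cytometry (on this read-out higher numbers stand for an effect only at larger amounts of compound and lower numbers for an effect already at smaller amounts), compound 1 (`N#Cc1ncc2nc1OCC/C=C\COc1ccc(Br)cc1NC(=O)N2`) gives > 10000 nM as a limit of the assay and not a number. Compound 2 (`COc1ccc2c(c1)NC(=O)Nc1cnc(C#N)c(n1)OCCCCCO2`) gives > 10000 nM and that too is only a limit. Compound 2 thus stands at the limit of > 10000 nM in this assay, at which 2 of the 2 values shown sit, without a number of its own.

Compound 3 (`N#Cc1ncc2nc1OCCCCCOc1ccc(CCO)cc1NC(=O)N2`) keeps the core of compound 2 but carries 2-hydroxyethyl in place of methoxy on an aromatic carbon. Going by the values given here, no measured step between related compounds is available to size this change, so only a small move toward lower numbers in this assay is expected, and it may stay within the scatter. The expected change, an at least 1.1-fold lower number from compound 2 to compound 3 (0.04 log units; that floor lies within the scatter), is therefore modest and uncertain. For compound 3 the estimated value is 9000 nM with an expected range from 2500 nM to 30000 nM in this read-out.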

Compound 3, half-maximal effective concentration: > 10000 nM
Compound 3 ended at the assay's limit (the forecaster's own chance of this, stated with the estimate: 60%); middle value at least 1.1-fold (0.04 log units) away from the limit.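

Going by these compounds alone, compound 2 and compound 3 both stop at a limit of this assay, so no step between them can be read: the limit of > 10000 nM in this assay, at which 3 of the 3 values shown sit.

The compounds shown leave open whether any change on the shared core would give a readable value in this assay.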